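Aryl sulfonamides on an imidazolidinone-bearing core

This account rests on a few compounds, and the source may have more. Where it says the series, first, only, none or still open, it means among the compounds named here.

Going by the values given here, compound 2 `Cc1cc(C)cc(NS(=O)(=O)c2ccc(N3CCNC3=O)cc2)c1` gives the lowest number of the two values so far in a functional assay on HT-29 cells (Homo sapiens) for antiproliferative activity, read by sulforhodamine B assay, with a stated time of 48 h; on this read-out lower numbers stand for stronger inhibition and higher numbers for weaker inhibition: compound 2 gives 82 nM, while compound 1 `O=C1NCCN1c1ccc(S(=O)(=O)Nc2ccc(F)cc2)cc1` gives 370 nM. Among the compounds with values here, the one measured step, a 4.5-fold lower number from compound 1 to compound 2 (0.65 log units; beyond the scatter), shows that the aryl group on the sulfonamide nitrogen matters. Compound 3 `Cc1ccccc1NS(=O)(=O)c1ccc(N2CCNC2=O)cc1` differs from compound 2 by 2-methylphenyl in place of 3,5-dimethylphenyl on a sulfonamide nitrogen. Within the data shown here, no measured step covers this exact exchange, so compound 3 is expected to land between the two measured values, a modest rise expected as a 2.4-fold higher number from compound 2 to compound 3 (0.39 log units; beyond the scatter), giving an estimate for compound 3 of 200 nM within 70 nM to 600 nM.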

Compound 3, half-maximal inhibitory concentration: 200 nM
Beside the measured number, compound 3's estimate shows no gap at the digits printed; measured number inside the range.
By their numbers in this assay, from the lowest: compound 2; then compounds 3 and 1 (each within the scatter of the next).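

With a 2.4-fold higher number from compound 2 to compound 3 (0.39 log units; beyond the scatter) in this assay the 3,5-dimethylphenyl group holds its lead over a second aryl group on the sulfonamide nitrogen, not only over 4-fluorophenyl. With a 1.9-fold lower number from compound 1 to compound 3 (0.27 log units; within the scatter) the 2-methylphenyl and 4-fluorophenyl groups cannot be told apart at this position, so only compound 2 stands clear of the others. Nothing available explains these differences.

Still open, going by these compounds, is how an aryl ring carrying a methoxy group or a carboxylic acid would fare on this nitrogen. The same holds for a plain alkyl chain in place of the aryl group.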